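Shifting the Hydroxyl on the Second Phenyl Arm

This account rests on a few compounds, and the source may have more. Where it says the series, first, only, none or still open, it means among the compounds named here.

Compound 1, `Oc1cccc(-c2cc(-c3cccc(F)c3)cc(-c3ccccc3O)n2)c1`, in a functional assay on DU-145 cells (Homo sapiens) for inhibition (on this read-out lower numbers stand for stronger inhibition and higher numbers for weaker inhibition), gave > 50000 nM, which is a limit of the assay and not a number.
Compound 2, `Oc1ccc(-c2cc(-c3cccc(F)c3)cc(-c3cccc(O)c3)n2)cc1`, in this assay gave 2700 nM.
Compound 3, `Oc1ccc(-c2cc(-c3cccc(F)c3)cc(-c3ccc(O)cc3)n2)cc1`, has not yet been measured in this assay.

Among the measured compounds shown here, compound 2 therefore holds the only number in this assay; the other value is the limit of > 50000 nM in this assay, at which 1 of the 2 values shown sits, and so no ordering among measured compounds can be read beyond that. For the measured compounds named here, the single measured step, an at least 18-fold lower number from compound 1 to compound 2 (1.26 log units; beyond the scatter), is large and beyond the scatter, and it concerns a 4-hydroxyphenyl entering in place of another hydroxyphenyl. The change now considered is 4-hydroxyphenyl in place of 3-hydroxyphenyl on an aromatic carbon. It is not the same change: the group leaving is 3-hydroxyphenyl rather than 2-hydroxyphenyl. It bears on it in that a 4-hydroxyphenyl again enters. A step in the same direction, smaller than the measured one, is expected in this assay, possibly within the scatter. Compound 3 is thus estimated at 1500 nM, between 500 nM and 5000 nM, which means an expected step of a 1.8-fold lower number from compound 2 to compound 3 (0.26 log units; within the scatter).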

Compound 3, half-maximal inhibitory concentration: 9290 nM
Compound 3: the middle estimate sits 6.2-fold (0.79 log units) below what was measured; the measured number lies above the stated range.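

In this assay, the change at this position, on an aromatic carbon next to the ring nitrogen, runs in the opposite direction to the earlier step: there is a 3.4-fold higher number from compound 2 to compound 3 (0.54 log units; beyond the scatter). A 4-hydroxyphenyl entering therefore does not lower the number in every case, as the earlier step alone might have suggested, and what it does here differs with the group it replaces and with the rest of the compound, since compound 2 and compound 3 carry the same atoms joined differently and the hydroxyl's place on this arm is the only difference between them. The earlier step, with a 2-hydroxyphenyl leaving, cannot be set against this one by size, as it starts from a value that is a limit and not a number: the limit of > 50000 nM in this assay, at which 1 of the 3 values shown sits.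

Whether the hydroxyl itself matters at this position remains open, since a methoxy group, an amine or a carboxylic acid on this phenyl arm is not among the compounds shown. Also open, going by these compounds, is whether the same shift would give a step of this direction and size on the other hydroxyphenyl arm, or with something other than the 3-fluorophenyl group on the core.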